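From hydroxy to methoxy on compound 2

A few compounds are considered here, and "the series" means these few. Any claim that something is new, unique, unknown or untested is made for them only; others in the source may bear on it.

Measured in an ADME assay on LLC-PK1 cells (Sus scrofa) for cytotoxicity, read by neutral red uptake; a lower number here means a stronger inhibitor, a higher number a weaker inhibitor:
- Compound 1 `COC(/C=C/c1ccc(O)cc1)=C1\C(=O)C=C(C)C1=O`: 3.4 ug/mL
- Compound 2 `CC1=CC(=O)/C(=C(O)/C=C/c2ccc(Cl)cc2)C1=O`: 6 ug/mL

Only these two compounds have been measured so far. Compound 2, at 6 ug/mL, and compound 1, at 3.4 ug/mL, lie within the scatter of each other, so the numbers do not separate them.

Compound 3 `COC(/C=C/c1ccc(Cl)cc1)=C1\C(=O)C=C(C)C1=O` comes from compound 2 by a single change methyl in place of hydrogen on an oxygen on an unsaturated carbon, which turns hydroxy to methoxy. For the measured compounds named here, no measured pair shows this change alone, so its size in this assay remains unknown. Compound 1, at 3.4 ug/mL, carries the same methoxy, but it differs from compound 3 in a second place and offers only indirect guidance. On these data alone, no step beyond the scatter is therefore expected, and the direction stays open. The estimate is a step of a 1.2-fold lower number from compound 2 to compound 3 (0.08 log units; within the scatter). Compound 3 is expected at 5 ug/mL, with an estimated range from 2.2 ug/mL to 11 ug/mL.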

Compound 3, half-maximal inhibitory concentration: 3.1 ug/mL
Estimate against measurement, compound 3: 1.6-fold (0.21 log units) above; measured number inside the range.
By their numbers in this assay, from the lowest: compounds 3, 1 and 2 (each within the scatter of the next).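

In this assay, for the compounds shown here, the change from hydroxy to methoxy now has a direct reading for the first time: methyl in place of hydrogen on an oxygen on an unsaturated carbon gives a 1.9-fold lower number from compound 2 to compound 3 (0.29 log units; within the scatter) and so does not separate the two compounds. Compound 3 also provides the first reading of a change on the aromatic ring, where chloro in place of hydroxy on an aromatic carbon gives a 1.1-fold lower number from compound 1 to compound 3 (0.04 log units; within the scatter) and again leaves the pair inseparable, so neither single change shown here moves the number beyond the scatter. No measured evidence is available to account for either step.

On these data alone, the three compounds cover only hydroxy and methoxy on the oxygen-bearing chain carbon and only hydroxy and chloro on the aromatic carbon, and each change has a single reading on one partner compound, so it remains open whether either step would hold on another partner. Also open, as far as these compounds go, is whether a longer chain such as ethyl on that oxygen, or an amine or a carboxylic acid on the aromatic carbon, would give a step beyond the scatter.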